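This account rests on a few compounds, and the source may have more. Where it says the series, first, only, none or still open, it means among the compounds named here.

The series shares one core; compound 1 is `COC(=O)c1c(Nc2ccc(C)cc2)sc(C(=O)c2ccc(OC)cc2)c1C`, compound 2 is `COC(=O)c1c(Nc2ccccc2)sc(C(=O)c2ccc(C)cc2)c1C` and compound 3, not yet measured, is `COC(=O)c1c(Nc2ccc(C)cc2)sc(C(=O)c2ccc(C)cc2)c1C`. In a functional assay, with a stated time of 150 min, tested at 5 ug/mL (a lower number here means a weaker effect, a higher number a stronger effect of the compound at the concentration tested), compound 1 gives "not active" (no number reported), with no number attached to that entry. In this assay compound 2 gives 2.08%, the only figure in the set, and it is a small activity, so compound 2 shows little effect in what the numbers show, with compound 1 beside it as an entry without a figure. Compound 3 differs from compound 2 in one place: methyl in place of hydrogen on an aromatic carbon. Among the measured compounds shown here, no step between measured compounds is available for this change, and the values of compound 1 and compound 2 only show that both sit at or near the floor of this assay. The expected step of a number 0.9 percentage points higher from compound 2 to compound 3 (within the scatter) is none beyond the scatter, with no direction to call. For compound 3 the estimate in this assay is 3%, expected to fall between -5% and 12%, with a fair chance that compound 3 is again reported only as not active.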

Compound 3, a percentage reported as activity, at one concentration (the size of the read-out at that concentration, not a potency): "not active" (no number reported)
For compound 3 the study gives words and no number; no gap can be computed for the estimate.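

In this assay, among the compounds shown here, compound 3 gives "not active" (no number reported) and compound 2 gives 2.08%, so no step between them can be read. No supporting measurement bears on this result. Whether phenyl to 4-methylphenyl changes the effect at all stays open, as does whether any compound shown has a clear effect in this assay.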